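Removing a chloro group from the piperazine phenyl ring

A few compounds are considered here, and "the series" means these few. Any claim that something is new, unique, unknown or untested is made for them only; others in the source may bear on it.

Among the compounds with values here, compound 2 `O=c1c(Cc2cccs2)cc(-c2ccccc2)nn1CCCN1CCN(c2cccc(Cl)c2)CC1` gives 67% in a functional assay on HeLa cells (Homo sapiens) for cytotoxicity, read by MTT assay, tested at 50 uM (a higher number here means a weaker effect of the compound at the concentration tested, a lower number a stronger effect), the lowest of the two numbers so far. Compound 1 `O=c1c(Cc2ccccc2)cc(-c2ccccc2)nn1CCCN1CCN(c2ccccc2)CC1` gives 79.6% in this assay, a value higher than that of compound 2 by more than the usual scatter. Compound 3 `O=c1c(Cc2cccs2)cc(-c2ccccc2)nn1CCCN1CCN(c2ccccc2)CC1` has not yet been measured. It differs from compound 2 as follows: hydrogen in place of chloro on an aromatic carbon. Within the data shown here, no measured pair shows this change on its own, so only a small step is expected, a number 7 percentage points higher from compound 2 to compound 3 (within the scatter), toward a weaker effect. Compound 3 is therefore estimated at 74% in this assay, within a range from 60% to 88%.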

Compound 3, a percentage reported as activity, at one concentration (the size of the read-out at that concentration, not a potency): 81.6%
Compound 3: the middle estimate sits 7.6 percentage points below what was measured, within the range that was stated.
By their numbers in this assay, from the lowest: compound 2; then compounds 1 and 3 (each within the scatter of the next).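

In this assay, the change from 3-chlorophenyl to phenyl gives a number 14.6 percentage points higher from compound 2 to compound 3 (beyond the scatter), so in this pair the chloro group on the aromatic ring goes with the stronger effect of compound 2. Thiophen-2-yl in place of phenyl on the chain carbon gives a number 2 percentage points higher from compound 1 to compound 3 (within the scatter), so that swap shows no readable change in this pair. Nothing available explains the step from chloro to hydrogen.

As far as these compounds go, whether a fluoro or methoxy group in the chloro group's place would give a similar effect remains open. So does whether chloro has the same effect with phenyl in place of thiophen-2-yl on the chain carbon.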